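The source may hold more compounds than are shown below. What is called first, only, known or untested is meant among the compounds shown, and "the series" means these compounds.

Compound 1 `CNC(=O)CC1CCc2cc(OC)c(OC)cc21` gives 15.6% in a functional assay on the whole organism (strain Wistar) for inhibition, with Rattus norvegicus as the target, read by paw edema, with stated times of 60 min and 1 h, at a dose of 100 mg/kg by the oral route; a lower number here means less inhibition, a higher number more inhibition at the dose given (going by the name of the read-out).
Compound 2 `COc1cc2c(cc1OC)C(CC(=O)N(C)C)CC2` gives 25% in this assay.
Compound 3 `COc1cc2c(cc1OC)C(CC(=O)NC(C)C)CC2` gives 31.3% in this assay.

Compound 3 has the highest of the three numbers, yet its edge over compound 2 is small: the step of a number 6.3 percentage points higher from compound 2 to compound 3 (within the scatter) stays within the scatter, so the two cannot be told apart. Only against compound 1 does compound 3 stand out, as the step of a number 15.7 percentage points higher from compound 1 to compound 3 (beyond the scatter) shows. The step from compound 1 to compound 2, a number 9.4 percentage points higher from compound 1 to compound 2 (within the scatter), is also within the scatter.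

Compound 4 `COc1cc2c(cc1OC)C(CC(=O)N1CCCC1)CC2` is the next structure, reached from compound 3 by the change (pyrrolidin-1-yl in place of isopropylamino on a carbonyl carbon). Among the measured compounds shown here, two measured steps bear on this: the step of a number 9.4 percentage points higher from compound 1 to compound 2 (within the scatter), where the amide hydrogen was exchanged for a methyl group, and the step of a number 6.3 percentage points higher from compound 2 to compound 3 (within the scatter), where dimethylamino and isopropylamino gave numbers within the scatter of each other. For the measured compounds named here, both steps are small, and nothing among the measured compounds suggests that a pyrrolidin-1-yl group would behave differently from these other amide groups. The step of a number 3.3 percentage points lower from compound 3 to compound 4 (within the scatter) is therefore expected to stay within the scatter, with no clear direction. Compound 4 is estimated at 28% in this assay, with a range from 15% to 40%.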

Compound 4, a percentage reported as inhibition, in the whole organism at one dose (the size of the read-out at that dose, not a potency): 4.69%
Estimate against measurement, compound 4: 23.3 percentage points above, and the stated range ends above it.
By their numbers in this assay, from the lowest: compound 4; then compounds 1, 2 and 3 (each within the scatter of the next, the first and the last beyond it).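

The amide group at this place, on a carbonyl carbon whose other neighbour is a saturated chain carbon, can matter far more in this assay than the first three compounds suggested: pyrrolidin-1-yl gives a number 26.6 percentage points lower from compound 3 to compound 4 (beyond the scatter) and, even against the lowest earlier compound, a number 10.9 percentage points lower from compound 1 to compound 4 (beyond the scatter). Losing the amide hydrogen alone does not account for this, since compound 2 also has none on that nitrogen, and yet the change from dimethylamino to pyrrolidin-1-yl gives a number 20.3 percentage points lower from compound 2 to compound 4 (beyond the scatter). Nothing measured here explains why the ring gives so low a number.

The compounds shown leave open whether the low number goes with the five-membered ring in particular or with any amide nitrogen whose substituents are larger than methyl groups: piperidin-1-yl or morpholin-4-yl would test the ring, and open-chain diethylamino would test the need for a ring at all. They also leave open whether a secondary amide with a longer chain, such as butylamino, would stay close to compound 3 or fall away as well.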